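Cyano in place of methoxy on the pyrrole carboxylic acid series

A few compounds are considered here, and "the series" means these few. Any claim that something is new, unique, unknown or untested is made for them only; others in the source may bear on it.

Measured compounds:
compound 1 `O=C(O)C1CCN(c2ccccc2Cl)C1` 19000 nM
compound 2 `COc1c(Cl)cccc1-n1c(C)cc(C(=O)O)c1C` 800 nM
compound 3 `Cc1cc(C(=O)O)c(C)n1-c1cccc(F)c1` 1500 nM

In an assay on cells for inhibition of Palmitoleoyl-protein carboxylesterase NOTUM variant C330S (Homo sapiens), read by fluorescence, with a stated time of 40 min (on this read-out lower numbers stand for stronger inhibition and higher numbers for weaker inhibition), compound 2 gives the lowest of the three numbers. Compound 3 comes nearest, within the scatter, while compound 1 is a large distance away, beyond the scatter. Compound 4 `Cc1cc(C(=O)O)c(C)n1-c1cccc(Cl)c1C#N` has not been measured. It differs from compound 2 by cyano in place of methoxy on an aromatic carbon, with the new group ortho to a chloro group. Within the data shown here, no measured pair shows this change, so its size is not known from these data. The expected step from compound 2 to compound 4 is a 1.6-fold lower number from compound 2 to compound 4 (0.20 log units; within the scatter), estimated as small and possibly within the scatter. Compound 4 is therefore expected to give about 500 nM, with a range from 150 nM to 1800 nM.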

Compound 4, half-maximal inhibitory concentration: 2000 nM
Beside the measured number, compound 4's estimate is 4.0-fold (0.60 log units) below it, outside the stated range (above it).
By their numbers in this assay, from the lowest: compounds 2, 3 and 4 (each within the scatter of the next, the first and the last beyond it); then compound 1.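

In this assay, cyano in place of methoxy on an aromatic carbon, ortho to a chloro group, gives a 2.5-fold higher number from compound 2 to compound 4 (0.40 log units; beyond the scatter) and so shows that this position responds to the exchange, with cyano giving no gain over methoxy. It is the only change in one place among these compounds, and its size is modest. Nothing available accounts for the direction of this step.

From the compounds shown here alone, whether an amine, a hydroxyl or a longer ether chain at this position would give a lower number remains open. So does whether the same step would hold on a ring lacking the chloro group.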